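The source may hold more compounds than are shown below. What is called first, only, known or untested is meant among the compounds shown, and "the series" means these compounds.

Compounds measured so far: compound 1 `Cn1ccc2c(Oc3ccc(NC(=O)c4nn(-c5ccccc5)ccc4=O)cc3F)ccnc21` and compound 2 `Cn1ccc2c(Oc3ccc(NC(=O)c4nn(-c5ccc(Cl)c(F)c5)ccc4=O)cc3F)ccnc21`; not yet measured: compound 3 `Cn1ccc2c(Oc3ccc(NC(=O)c4nn(-c5ccc(Cl)c(C(F)(F)F)c5)ccc4=O)cc3F)ccnc21`.

In a functional assay on MCF7 cells (Homo sapiens) for cytotoxicity, read by MTT assay, with a stated time of 72 h (a higher number here means a weaker inhibitor, a lower number a stronger inhibitor), compound 1 returns only a limit, > 60000 nM. In this assay compound 2 gives 16600 nM, the only number shown. Within the data shown here, the one measured step, an at least 3.6-fold lower number from compound 1 to compound 2 (0.55 log units; beyond the scatter), concerns the ring on the aromatic nitrogen as a whole and not the change at hand. Compound 3 differs from compound 2 by trifluoromethyl in place of fluoro on an aromatic carbon. Among the measured compounds shown here, no measured step tests this exchange, so compound 3 is expected to stay close to compound 2, an estimated step of a 1.3-fold lower number from compound 2 to compound 3 (0.11 log units; within the scatter) within the scatter. Compound 3 is thus estimated at 13000 nM, between 4000 nM and 45000 nM.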

Compound 3, half-maximal inhibitory concentration: 18400 nM
Compound 3: middle estimate off by 1.4-fold (0.15 log units), on the low side, within the range that was stated.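

In this assay, trifluoromethyl and fluoro, ortho to a chloro group, cannot be told apart at this position, a 1.1-fold higher number from compound 2 to compound 3 (0.04 log units; within the scatter). The 4-chloro-3-(trifluoromethyl)phenyl group also stands clear of plain phenyl, an at least 3.2-fold lower number from compound 1 to compound 3 (0.51 log units; beyond the scatter), so the earlier step from phenyl does not depend on fluoro being the group at this position. Compound 1 gives only a limit of the assay, so the full size of that step stays unknown: the limit of > 60000 nM in this assay, at which 1 of the 3 values shown sits.

Whether the chloro group alone accounts for the step from phenyl remains open. So does the effect of a methoxy group, an amine or a nitrile at this position.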